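Exchanging 3-methylphenyl for tert-butyl in compound 1

This account rests on a few compounds, and the source may have more. Where it says the series, first, only, none or still open, it means among the compounds named here.

In a functional assay on a cell-free system (plasma, Homo sapiens), with a stated time of 3 min (on this read-out higher numbers stand for weaker inhibition and lower numbers for stronger inhibition), compound 1 (`Cc1cccc([C@@H](O)C(=O)N2N=CC[C@H]2C(=O)NCc2cc(Cl)ccc2-n2cnnn2)c1`) gives 830 nM while compound 2 (`CC(C)(C)[C@@H](O)C(=O)N1C[C@@H]2C[C@@H]2[C@H]1C(=O)NCc1cc(Cl)ccc1-n1cnnn1`) gives 570 nM and compound 3 (`O=C(NCc1cc(Cl)ccc1-n1cnnn1)[C@@H]1[C@H]2C[C@H]2CN1C(=O)[C@H](O)c1ccccc1`) gives 960 nM in the same test. Compound 1 lies within the scatter of both others, so the numbers do not separate it from either. Compound 4 (`CC(C)(C)[C@@H](O)C(=O)N1N=CC[C@H]1C(=O)NCc1cc(Cl)ccc1-n1cnnn1`) has not been measured. It carries tert-butyl in place of 3-methylphenyl on a saturated chain carbon bound to a carbonyl carbon and an oxygen on a saturated carbon, and the change amounts to tert-butyl in place of 3-methylphenyl on a saturated chain carbon bound to a carbonyl carbon and an oxygen on a saturated carbon in all. Going by the values given here, one measured step bears on this exchange, and it runs the opposite way on a different core: a 1.7-fold higher number from compound 2 to compound 3 (0.23 log units; within the scatter) for phenyl in place of tert-butyl. That step stays within the scatter, so at most a slight shift towards a lower number is expected, and nothing beyond the scatter. The expected change is a 1.5-fold lower number from compound 1 to compound 4 (0.18 log units; within the scatter) and it would remain within the scatter. For compound 4 the estimated value is 550 nM with an expected range from 260 nM to 1150 nM in this test.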

Compound 4, half-maximal inhibitory concentration: 1400 nM
The estimate for compound 4 lay 2.5-fold (0.41 log units) below the measured number; measured number outside the range, above it.
By their numbers in this assay, from the lowest: compounds 2, 1, 3 and 4 (each within the scatter of the next, the first and the last beyond it).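

On the core of compound 1, the exchange gives a 1.7-fold higher number from compound 1 to compound 4 (0.23 log units; within the scatter) in this assay, so removing the six-membered aromatic ring of carbon only from this saturated chain carbon, and with it going from 7 heavy atoms to 4, does not move the number beyond the scatter. The earlier step, a 1.7-fold higher number from compound 2 to compound 3 (0.23 log units; within the scatter), also stays within the scatter, so on neither core do the numbers separate tert-butyl from an aromatic group at this position. Nothing measured here accounts for the result.

What the compounds shown leave open is whether any group at this position can move the number beyond the scatter, such as an amine, a carboxylic acid or a longer chain. They also leave open how plain phenyl would compare with 3-methylphenyl on the core of compound 1.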